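Neopentyl in place of 2-chlorobenzyl on the shared core

A few compounds are considered here, and "the series" means these few. Any claim that something is new, unique, unknown or untested is made for them only; others in the source may bear on it.

Of the compounds shown here, three on one core have been read in an in vitro functional assay on cells for agonist activity at Bombesin receptor subtype-3 (Homo sapiens), read by luminescence and calcium flux; on this read-out lower numbers stand for an effect already at smaller amounts and higher numbers for an effect only at larger amounts of compound. Compound 1 `O=C(O)c1ccccc1-c1ccc(CCc2ncc(C3CCCCC3)[nH]2)cc1` gives 375 nM, compound 2 `O=C(O)c1ccccc1-c1ccc(CCc2ncc(CC3CCCC3)[nH]2)cc1` gives 133 nM, and compound 3 `O=C(O)c1ccccc1-c1ccc(CCc2ncc(Cc3ccccc3Cl)[nH]2)cc1` gives 292 nM. Compound 3 thus stands second highest of the three numbers; compound 1 sits within the scatter of it, and only compound 2 is set apart, by a 2.2-fold higher number from compound 2 to compound 3 (0.34 log units; beyond the scatter). Among the saturated groups, a 2.8-fold lower number from compound 1 to compound 2 (0.45 log units; beyond the scatter) is also a modest step.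

Compound 4 `CC(C)(C)Cc1cnc(CCc2ccc(-c3ccccc3C(=O)O)cc2)[nH]1` is compound 3 with tert-butyl in place of 2-chlorophenyl on a saturated chain carbon bound to an aromatic carbon. The step that bears on this is a 2.2-fold higher number from compound 2 to compound 3 (0.34 log units; beyond the scatter): there a saturated ring on the saturated chain carbon bound to an aromatic carbon gave the lower number and 2-chlorophenyl the higher. The present change runs the other way, 2-chlorophenyl out and a saturated branch in, so a modest lowering in this assay is expected rather than none. Tert-butyl carries no ring, and no measured step involves it, so the range is kept wide.

For compound 4 the expected value in this assay is 180 nM, with a range from 70 nM to 450 nM. That amounts to an expected step of a 1.6-fold lower number from compound 3 to compound 4 (0.21 log units; within the scatter).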

Compound 4, half-maximal effective concentration: 106 nM
Estimate against measurement, compound 4: 1.7-fold (0.23 log units) above; the measured number falls inside the stated range.
By their numbers in this assay, from the lowest: compounds 4 and 2 (each within the scatter of the next); then compounds 3 and 1 (each within the scatter of the next).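

In this assay the new step of a 1.3-fold lower number from compound 2 to compound 4 (0.10 log units; within the scatter) stands within the scatter, so at the saturated chain carbon bound to an aromatic carbon, tert-butyl with no ring reads the same as cyclopentyl, and a saturated ring is not required there for a number in this range. Taking out 2-chlorophenyl gives a 2.8-fold lower number from compound 3 to compound 4 (0.44 log units; beyond the scatter) and is beyond the scatter, so with compound 2 there are now two saturated groups at this place that stand apart from the 2-chlorophenyl of compound 3, while the comparison with cyclohexyl on an aromatic carbon gives a 3.5-fold lower number from compound 1 to compound 4 (0.55 log units; beyond the scatter) and also lies beyond the scatter. Nothing measured here accounts for these differences.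

Still open, from the compounds shown here alone, is whether an unbranched chain such as n-butyl at the same place reads like tert-butyl, or whether the branching matters. Also open, going by these compounds, is how far a hydroxyl or an amine on the neopentyl group would be tolerated, and whether a phenyl without chlorine would read like 2-chlorophenyl or like the saturated groups.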